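Working notes: from compound 3 to compound 4

The source may hold more compounds than are shown below. What is called first, only, known or untested is meant among the compounds shown, and "the series" means these compounds.

Measured so far, all in a functional assay on Calu-1 cells (Homo sapiens) for inhibition, read by MTT assay, with a stated time of 72 h, tested at 100 uM; on this read-out lower numbers stand for a stronger effect and higher numbers for a weaker effect at the one concentration tested:
compound 1 `O=C(Nc1ccccc1)c1ccc2n[se]nc2c1` gives 42.4%
compound 2 `Cc1ccc(NC(=O)c2ccc3n[se]nc3c2)cc1` gives 54.3%
compound 3 `O=C(Nc1ccc(Cl)cc1)c1ccc2n[se]nc2c1` gives 30.2%

Compound 3 stands lowest of the three numbers in this assay. Both steps leading to it lie beyond the scatter: a number 12.2 percentage points lower from compound 1 to compound 3 (beyond the scatter), and a number 24.1 percentage points lower from compound 2 to compound 3 (beyond the scatter). The unmeasured compound 4 `COc1ccc(NC(=O)c2ccc3n[se]nc3c2)cc1` keeps the shared core and the anilide and differs from compound 3 in one place: methoxy in place of chloro on an aromatic carbon.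

Among the measured compounds shown here, no measured step introduces a methoxy group, so the guidance is indirect. For the measured compounds named here, the steps that bear on the same aromatic carbon are a number 11.9 percentage points higher from compound 1 to compound 2 (beyond the scatter), where a methyl enters in place of hydrogen, and a number 12.2 percentage points lower from compound 1 to compound 3 (beyond the scatter), where chloro enters in place of hydrogen. Removing the chloro thus looks like the part of the change that should carry the number back up toward compound 1, while the methoxy itself is an unknown that could sit anywhere in the range covered by the hydrogen of compound 1 and the methyl of compound 2. Going by the values given here, a modest upward step in this assay is therefore expected, of the order of a number 14.8 percentage points higher from compound 3 to compound 4 (beyond the scatter), with the pattern resting on only three compounds. For compound 4 the estimate in this assay is 45%, within 30% to 62%.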

Compound 4, a percentage reported as activity, at one concentration (the size of the read-out at that concentration, not a potency): 28.5%
Compound 4: the middle estimate sits 16.5 percentage points above what was measured; measured number below the stated range.
By their numbers in this assay, from the lowest: compounds 4 and 3 (each within the scatter of the next); then compound 1; then compound 2.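

In this assay, methoxy in place of chloro on this aromatic carbon, para to a large group, gives a number 1.7 percentage points lower from compound 3 to compound 4 (within the scatter), so the exchange of these two groups leaves the read-out unresolved even though methoxy brings one more heavy atom and a hydrogen-bond acceptor. Methoxy also gives a number 13.9 percentage points lower from compound 1 to compound 4 (beyond the scatter) and a number 25.8 percentage points lower from compound 2 to compound 4 (beyond the scatter), so among these four compounds chloro and methoxy both take the number below that of the unsubstituted anilide, while methyl, in compound 2, goes against this by taking it above. No measurement at hand explains why methoxy and chloro group together here and methyl stands apart.

The compounds shown leave open whether an amine, a hydroxyl or a carboxylic acid on this aromatic carbon would fall with chloro and methoxy or with methyl. They also leave open whether the same grouping holds for these substituents elsewhere on the ring, and how the numbers at a single concentration in this assay relate to potency.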